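A few compounds are considered here, and "the series" means these few. Any claim that something is new, unique, unknown or untested is made for them only; others in the source may bear on it.

Measured compounds in a functional assay on SK-MEL-28 cells (Homo sapiens) for cytotoxicity, read by MTT assay; on this read-out higher numbers stand for weaker inhibition and lower numbers for stronger inhibition:

- compound 1 `O=S(=O)(NCCCNc1nccc(-c2c(-c3cccc(F)c3)nc3sccn23)n1)c1ccc(Br)cc1`: 9400 nM
- compound 2 `O=S(=O)(NCCNc1nccc(-c2c(-c3cccc(F)c3)nc3sccn23)n1)c1ccc(Br)cc1`: 13500 nM
- compound 3 `O=C(NCCNc1nccc(-c2c(-c3cccc(F)c3)nc3sccn23)n1)c1c(F)cccc1F`: 11400 nM

Compound 1 gives the lowest of the three numbers, but its separation from the other two is small: a 1.4-fold higher number from compound 1 to compound 2 (0.16 log units; within the scatter) and a 1.2-fold higher number from compound 1 to compound 3 (0.08 log units; within the scatter), both within the scatter, and likewise a 1.2-fold lower number from compound 2 to compound 3 (0.07 log units; within the scatter). The three compounds are therefore not distinguishable in this assay.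

Compound 4 `O=S(=O)(NCCCNc1nccc(-c2c(-c3cccc(F)c3)nc3sccn23)n1)c1ccc(C(F)(F)F)cc1` is the next step from compound 1. The change is trifluoromethyl in place of bromo on an aromatic carbon; the whole of the shared core, the chain and the sulfonamide are kept. Among the compounds with values here, none of the measured steps touches the substituent on the sulfonyl aryl ring: the measured steps change the chain length and exchange sulfonyl for carbonyl, and each of them stays within the scatter. Within the data shown here, there is thus no measured precedent for this substituent change, and the series so far shows no movement at all, so no step beyond the scatter is expected in this assay in either direction.

Compound 4 is expected to give about 10000 nM, with a range of 4500 nM to 22000 nM, which means an expected step of a 1.1-fold higher number from compound 1 to compound 4 (0.03 log units; within the scatter).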

Compound 4, half-maximal inhibitory concentration: 11700 nM
The estimate for compound 4 lay 1.2-fold (0.07 log units) below the measured number; low and high end bracket the measured number.
By their numbers in this assay, from the lowest: compounds 1, 3, 4 and 2 (each within the scatter of the next).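

Trifluoromethyl in place of bromo, on an aromatic carbon para to a large group, is the first measured change on the sulfonyl aryl ring, and in this assay it gives a 1.2-fold higher number from compound 1 to compound 4 (0.10 log units; within the scatter) as its step. The exchange raises the count at this place from 1 heavy atom to 4 heavy atoms, yet 4-bromophenyl and 4-(trifluoromethyl)phenyl remain indistinguishable in this read-out, so this position now joins the chain and the sulfonyl-to-carbonyl exchange among the changes that give no step beyond the scatter. No measurement available here bears on the reason for this result.

Whether this position can move the number at all remains open, since bromo and trifluoromethyl are the only two groups shown there, and an amine, a carboxylic acid or a methoxy group at the same place could behave differently. Within the data shown here, also open is whether trifluoromethyl keeps the same standing on the two-carbon chain, or whether a longer chain than that of compound 4 departs from the narrow band held by the series so far.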